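The source may hold more compounds than are shown below. What is called first, only, known or untested is meant among the compounds shown, and "the series" means these compounds.

Compound 1 `c1ccc2c(-c3cn4ccnc4c(-c4ccc5ncn(C6CCCCC6)c5c4)n3)cccc2c1`: 13% in a functional assay on MCF7 cells (Homo sapiens) for inhibition, read by sulforhodamine B assay, with a stated time of 48 h, tested at 10 uM; a higher number here means more inhibition at the concentration tested (going by the name of the read-out), a lower number less inhibition
Compound 2 `CCc1ccc(-c2cn3ccnc3c(-c3ccc4ncn(Cc5ccccc5)c4c3)n2)cc1`: 58% in this assay
Compound 3 `O=Cc1ccc(-c2cn3ccnc3c(-c3ccc4ncn(Cc5ccccc5)c4c3)n2)cc1`: 47.8% in this assay

Compound 3 stands second highest of the three numbers in this assay; its nearest neighbour is compound 2, and the step of a number 10.2 percentage points lower from compound 2 to compound 3 (beyond the scatter) is beyond the scatter, while compound 1 lies far below it.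

Compound 4 `c1ccc(Cn2cnc3ccc(-c4nc(-c5cccc6ccccc56)cn5ccnc45)cc32)cc1` is not yet measured. Its change from compound 3 is naphthalen-1-yl in place of 4-formylphenyl on an aromatic carbon. Within the data shown here, the one measured step, a number 10.2 percentage points lower from compound 2 to compound 3 (beyond the scatter), touches the same group on the same aromatic carbon, but it swaps one substituent on a phenyl ring for another and does not involve naphthalen-1-yl, so it bears on the present step only loosely. Among the measured compounds shown here, compound 1 also carries naphthalen-1-yl and gives 13% in this assay, yet it differs from compound 4 on the benzimidazole nitrogen as well, so no single step to compound 4 can be read from it. For the measured compounds named here, with this thin basis, a downward step a number 15.8 percentage points lower from compound 3 to compound 4 (beyond the scatter) is expected, with wide uncertainty, because compound 1 at 13% is the only measured naphthalen-1-yl compound. Compound 4 is therefore estimated at 32% in this assay, within a range of 10% to 58%.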

Compound 4, a percentage reported as inhibition, at one concentration (the size of the read-out at that concentration, not a potency): 29.2%
Compound 4: middle estimate off by 2.8 percentage points, on the high side, within the range that was stated.
By their numbers in this assay, from the lowest: compound 1; then compound 4; then compound 3; then compound 2.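

In this assay, the position on the aromatic carbon, earlier probed only by swapping one substituent on a phenyl ring, now carries a group with two six-membered aromatic rings of carbon only: naphthalen-1-yl in place of 4-formylphenyl gives a number 18.6 percentage points lower from compound 3 to compound 4 (beyond the scatter), and naphthalen-1-yl in place of 4-ethylphenyl gives a number 28.8 percentage points lower from compound 2 to compound 4 (beyond the scatter), so among these three compounds the naphthalen-1-yl compound gives the lowest number. Among these compounds, the nitrogen substituent can also be read on its own for the first time, since with naphthalen-1-yl held fixed, benzyl in place of cyclohexyl on the aromatic nitrogen gives a number 16.2 percentage points higher from compound 1 to compound 4 (beyond the scatter), which shows that this second place also changes the read-out. Nothing at hand explains either kind of change.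

As far as these compounds go, it remains open whether a phenyl ring at this carbon bearing an amine, a carboxylic acid or a longer chain in place of ethyl or formyl would give a number closer to that of compound 2 or of compound 4. Also open, from the compounds shown here alone, is how cyclohexyl on the aromatic nitrogen would fare alongside 4-ethylphenyl on the aromatic carbon.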